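A few compounds are considered here, and "the series" means these few. Any claim that something is new, unique, unknown or untested is made for them only; others in the source may bear on it.

Of the compounds shown here, two have been measured in a physicochemical assay for lipophilicity, read by HPLC, in phosphate buffer, measured as chromatographic lipophilicity, at pH 7.4; on this read-out higher numbers stand for higher lipophilicity and lower numbers for lower lipophilicity. Compound 1, `COc1ccc2nc(C)cc(OC(C)C(=O)Nc3cc(C)cc(C)c3)c2c1`, gives 5.76 in this assay. Compound 2, `COc1ccc2nc(C)cc(OCC(=O)NCc3cc(C)cc(C)c3)c2c1`, gives 5.25 in this assay, the lower of the two numbers, standing below compound 1 by a gap beyond the usual scatter. Going by the values given here, no single-change pair exists between the two measured compounds, so the contribution of any one group cannot be read off directly.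

Compound 3 is `COc1ccc2nc(C)cc(OCC(=O)Nc3ccc(F)cc3)c2c1`. It differs from compound 2 as follows: 4-fluorophenyl in place of 3,5-dimethylbenzyl on an amide-type nitrogen. The change removes a larger hydrocarbon group and brings in a smaller one carrying a fluorine, so a downward step in this assay is expected rather than none. The step from compound 2 to compound 3 is expected to be a number 0.75 log units lower from compound 2 to compound 3 (beyond the scatter), likely beyond the scatter. On that basis compound 3 is expected to give about 4.5 in this assay, with a plausible range from 4 to 5; the measured value will show how far the estimate holds.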

Compound 3, distribution coefficient: 4.49
The estimate for compound 3 lay 0.01 log units above the measured number; the range from low to high includes it.
By their numbers in this assay, from the lowest: compound 3; then compound 2; then compound 1.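

In this assay, going by these compounds alone, the swap of 3,5-dimethylbenzyl for 4-fluorophenyl on an amide-type nitrogen gives a number 0.76 log units lower from compound 2 to compound 3 (beyond the scatter) and is the first step that can be tied to a single change. It shows that the group at this one place can move the reading past the scatter while the rest of the structure stays the same, something the earlier pair could not show, as those compounds differed in more than one place. Within the data shown here, the step has only this one example behind it, and no measurement at hand accounts for its size.

Among these compounds, the single step also bundles several differences, as the group that leaves has 9 heavy atoms, all carbon, and the group that enters has 7, one of them fluorine, so the shares of the fluorine, the two methyl groups and the benzyl carbon remain unseparated. Going by these compounds, it also remains open where a plain phenyl, a plain benzyl or a 4-chlorobenzyl group on the same nitrogen would fall relative to compound 2 and compound 3.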